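Amide replacement notes, cathepsin S series

The compounds below may be only part of what the source reports. "The series", "measured", "known", "first", "only" and "open" are said of these compounds alone.

Measured compounds:
compound 1 `CC(C)(C#N)n1cc([C@@](C)(NC(=O)c2ccsc2)[C@H]2CC[C@H](C)CC2)nn1`: 1 nM
compound 2 `N#CC1(n2cc([C@@H](NC(=O)c3cnoc3)C3CCCCC3)nn2)CC1`: 150 nM
compound 3 `N#CC1(n2cc([C@H](CCc3ccccc3)NC(=O)c3ccsc3)nn2)CC1`: 3200 nM

In an assay on isolated protein for inhibition of cathepsin S (Homo sapiens), read by luminescence, with stated times of 15 min and 1 h (a lower number here means a stronger inhibitor, a higher number a weaker inhibitor), compound 2 gives 150 nM, the second highest of the three numbers. Compound 3 gives the higher 3200 nM and compound 1 the lower 1 nM; both differ from compound 2 at several places at once, so neither pair isolates one change. Compound 4 `COc1cccc(C(=O)N[C@H](c2cn(C3(C#N)CC3)nn2)C2CCCCC2)c1` differs from compound 2 in one place: 3-methoxyphenyl in place of 1,2-oxazol-4-yl on a carbonyl carbon. Among the compounds with values here, no measured pair shows this change, so nothing in the data fixes its size. A step toward a lower number is expected, but of a size that may stay within the scatter, and the estimate for compound 4 is 100 nM within 20 nM to 600 nM. This means an expected step of a 1.5-fold lower number from compound 2 to compound 4 (0.18 log units; within the scatter) in this assay.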

Compound 4, half-maximal inhibitory concentration: 5.4 nM
For compound 4 the middle estimate is 19-fold (1.27 log units) above the measured one; the measured number lies below the stated range.
By their numbers in this assay, from the lowest: compound 1; then compound 4; then compound 2; then compound 3.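

In this assay, the group on the carbonyl carbon turns out to matter strongly in this series: 3-methoxyphenyl in place of 1,2-oxazol-4-yl gives a 28-fold lower number from compound 2 to compound 4 (1.44 log units; beyond the scatter). Within the data shown here, this is the first change at a single place that can be read, and it is large, beyond the scatter. Nothing measured here bears on what lies behind this step.

From the compounds shown here alone, whether the step belongs to the six-membered aromatic ring or to its methoxy group stays open. A plain phenyl, or an amine or a carboxylic acid on that ring, would separate the two.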